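The compounds below may be only part of what the source reports. "The series", "measured", "known", "first", "only" and "open" are said of these compounds alone.

Compound 1 `Clc1ccc2c(NCCNCc3ccc(-c4ccccc4)s3)ccnc2c1` gives 13800 nM
Compound 2 `Clc1ccc2c(NCCCNCc3ccc(-c4ccccc4)s3)ccnc2c1` gives 6720 nM
Compound 3 `COc1ccc(-c2ccc(CNCCCNc3ccnc4cc(Cl)ccc34)s2)cc1` gives 2230 nM

In an ADME assay on HepG2 cells (Homo sapiens) for cytotoxicity, read by MTT assay, with a stated time of 48 h (a higher number here means a weaker inhibitor, a lower number a stronger inhibitor), compound 2 stands in the middle of the three numbers, lower than compound 1 and higher than compound 3. Compound 4 `CC(=O)Nc1ccc(-c2ccc(CNCCCNc3ccnc4cc(Cl)ccc34)s2)cc1` differs from compound 2 by acetamido in place of hydrogen on an aromatic carbon and so has acetamido in place of hydrogen on an aromatic carbon, para to a large group. Within the data shown here, one measured step bears on this change: a 3.0-fold lower number from compound 2 to compound 3 (0.48 log units; beyond the scatter) with methoxy in place of hydrogen on an aromatic carbon. Among the measured compounds shown here, no measured compound carries acetamido, so this single modest step gives only thin support for expecting a modest fall in the number. The estimate a 1.9-fold lower number from compound 2 to compound 4 (0.28 log units; within the scatter) is therefore a somewhat smaller step in the same direction. For compound 4 the expected value is 3500 nM with an estimated range from 1500 nM to 8000 nM in this assay.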

Compound 4, half-maximal inhibitory concentration: 2080 nM
The estimate for compound 4 lay 1.7-fold (0.23 log units) above the measured number; measured number inside the range.
By their numbers in this assay, from the lowest: compounds 4 and 3 (each within the scatter of the next); then compound 2; then compound 1.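

In this assay, acetamido at this position, para to a large group, gives a 3.2-fold lower number from compound 2 to compound 4 (0.51 log units; beyond the scatter), so the lowering seen with methoxy is not confined to that one group. Acetamido in place of methoxy gives a 1.1-fold lower number from compound 3 to compound 4 (0.03 log units; within the scatter), so the two groups cannot be told apart here. Nothing measured gives a reason for either step.

As far as these compounds go, whether an amine or a carboxylic acid at this position would lower the number as well remains open. So does whether acetamido would have the same effect on the shorter chain of compound 1.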